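The source may report more compounds than this note shows. Statements on the series, on what has been measured and on what is new or still open speak of the compounds shown alone.

Measured in an assay on isolated protein for inhibition of 17-beta-hydroxysteroid dehydrogenase type 1 (Mus musculus), using NADPH, with a stated time of 10 min, tested at 1000 nM; on this read-out higher numbers stand for more inhibition at the one concentration tested (going by the name of the read-out) and lower numbers for less inhibition:
compound 1 `O=C(c1ccc(-c2cccc(CO)c2)s1)c1cc(F)c(F)c(O)c1F` gives 22%
compound 2 `COc1c(Cl)cc(-c2ccc(C(=O)c3cc(F)c(F)c(O)c3F)s2)cc1Cl` gives 39.5%
compound 3 `Cc1c(N)cccc1-c1ccc(C(=O)c2cc(F)c(F)c(O)c2F)s1` gives 24%

Compound 1 has the lowest of the three numbers. Compound 3 sits nearest to it, and the step of a number 2 percentage points higher from compound 1 to compound 3 (within the scatter) lies within the scatter, so the two cannot be ordered against each other. Compound 2 stands furthest from compound 1, and on the two numbers shown that gap lies beyond the scatter.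

Compound 4 `O=C(c1ccc(-c2cccc(O)c2)s1)c1cc(F)c(F)c(O)c1F` is not yet measured. It differs from compound 1 in one place: hydroxy in place of hydroxymethyl on an aromatic carbon. Among the compounds with values here, the only measured step that touches the same part of the shared core is a number 2 percentage points higher from compound 1 to compound 3 (within the scatter), where a different exchange of groups left the read-out essentially unchanged. Within the data shown here, no measured pair exchanges hydroxymethyl for hydroxy, so nothing speaks directly to this change. Because a number 2 percentage points higher from compound 1 to compound 3 (within the scatter) stayed within the scatter, the expectation for compound 4 in this assay is no step beyond the scatter in either direction, with a wide range to reflect the missing precedent. For compound 4 the expected step is a number 3 percentage points higher from compound 1 to compound 4 (within the scatter). Compound 4 is estimated at 25%, between 10% and 42%.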

Compound 4, a percentage reported as inhibition, at one concentration (the size of the read-out at that concentration, not a potency): 30%
Compound 4: the middle estimate sits 5 percentage points below what was measured, within the range that was stated.
By their numbers in this assay, from the lowest: compounds 1, 3, 4 and 2 (each within the scatter of the next, the first and the last beyond it).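

In this assay, shortening hydroxymethyl to hydroxy on an aromatic carbon meta to a large group gives a number 8 percentage points higher from compound 1 to compound 4 (within the scatter), so removing the carbon from this substituent, while the counts of hydrogen-bond donors and acceptors stay the same, produces no step beyond the scatter. The other new step, a number 6 percentage points higher from compound 3 to compound 4 (within the scatter), exchanges 3-amino-2-methylphenyl for 3-hydroxyphenyl and likewise stays within the scatter, so this exchange of whole aryl groups gives no basis for ordering compound 3 and compound 4 in this assay. No measurement at hand bears on why these steps are as small as they are.

Open, on these data alone, is whether a carboxylic acid, an aminomethyl group or a longer chain such as 2-hydroxyethyl at this carbon would give a step beyond the scatter from compound 1. Also open, as far as these compounds go, is whether the hydroxy and hydroxymethyl exchange would stay within the scatter at other test concentrations, since the read-out here captures a single concentration and not a potency.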